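Swapping a Methoxyphenyl for a Benzofuran Ring

This account rests on a few compounds, and the source may have more. Where it says the series, first, only, none or still open, it means among the compounds named here.

Compound 1, `CNC(=O)c1cc(C(=O)NC2CC2)cn(Cc2ccc(OC)cc2)c1=O`: 3
Compound 2, `CNC(=O)c1cc(C(=O)NC)c(=O)n(Cc2ccccc2)c1`: 2.4

Both were measured in a physicochemical assay for lipophilicity, at pH 7.4; on this read-out lower numbers stand for lower lipophilicity and higher numbers for higher lipophilicity. Of these two numbers compound 1 stands highest; the nearest, compound 2, lies lower by a gap beyond the usual scatter. Compound 3, `CNC(=O)c1cc(C(=O)NC2CC2)cn(Cc2cccc3occc23)c1=O`, has not yet been measured in this assay. It differs from compound 1 in one place: 1-benzofuran-4-yl in place of 4-methoxyphenyl on a saturated chain carbon bound to an aromatic nitrogen. Among the measured compounds shown here, no measured pair here shows a step of this kind, so the expectation rests on the change alone. A moderate upward step is expected, a number 0.60 log units higher from compound 1 to compound 3 (beyond the scatter). Compound 3 is thus estimated at 3.6, likely between 3.1 and 4.1.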

Compound 3, distribution coefficient: 3.4
Compound 3: middle estimate off by 0.20 log units, on the high side; the range from low to high includes it.
By their numbers in this assay, from the lowest: compound 2; then compound 1; then compound 3.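

In this assay, among the compounds shown here, exchanging the 4-methoxyphenyl group for a 1-benzofuran-4-yl group gives a number 0.40 log units higher from compound 1 to compound 3 (beyond the scatter) and is the first change here made in one place alone. It shows that this read-out responds to a swap of ring groups at this position on the shared core. The data offer no explanation for the size or direction of this step.

A single swap sets no trend for this position. As far as these compounds go, how an amine or a carboxylic acid on the same chain carbon would compare remains open.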